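The source may hold more compounds than are shown below. What is called first, only, known or untested is meant among the compounds shown, and "the series" means these compounds.

Working notes on the series, all read in an ADME assay on L1210/0 cells (Mus musculus) for cytotoxicity, with a stated time of 48 h; on this read-out lower numbers stand for stronger inhibition and higher numbers for weaker inhibition. Compound 1 `COCC#Cc1cn([C@H]2C[C@H](O)[C@@H](CO)O2)c(=O)[nH]c1=O` gives > 200000 nM, which is a limit of the assay. Compound 2 `C[S+]([O-])c1cn([C@H]2C[C@H](O)[C@@H](CO)O2)c(=O)[nH]c1=O` gives > 200000 nM, again a limit and not a number, so compound 2 has no readable place on the scale. Next comes compound 3 `CS(=O)(=O)Cc1cn([C@H]2C[C@H](O)[C@@H](CO)O2)c(=O)[nH]c1=O`, with the change a group of 5 heavy atoms (2 carbon, 2 oxygen, 1 sulfur; no ring) in place of a group of 3 heavy atoms (1 carbon, 1 oxygen, 1 sulfur; no ring), on an aromatic carbon: (methylsulfonyl)methyl enters on an aromatic carbon. Within the data shown here, the one measured step that bears on this, a step that the two limits leave unreadable from compound 1 to compound 2, also exchanges a group on an aromatic carbon, and its size cannot be read. With compound 1 and compound 2 both at the limit of > 200000 nM in this assay, at which 2 of the 2 values shown sit, no step beyond the scatter is expected in this assay, in either direction. The estimate for compound 3 is an expected 200000 nM, within an estimated range of 100000 nM to 400000 nM. This corresponds to an expected a number no higher from compound 2 to compound 3 (the limit leaves the size open).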

Compound 3, half-maximal inhibitory concentration: > 200000 nM
Compound 3: a limit, no number (the forecaster's own chance of this, stated with the estimate: 85%); the middle value lies on the limit itself.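

In this assay, among these compounds, compound 3 gives > 200000 nM, a limit of the assay and not a number, so no step among compound 1, compound 2 and compound 3 can be read. The compounds shown leave open how their groups on the aromatic carbon rank in this assay, and all three share one reading: the limit of > 200000 nM in this assay, at which 3 of the 3 values shown sit.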